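Replacing an isobutyl carbamate with a phenyl carbamate

The compounds below may be only part of what the source reports. "The series", "measured", "known", "first", "only" and "open" are said of these compounds alone.

Measured so far:
Compound 1 `CC(C)COC(=O)Nc1ccc([Se][Se]c2ccc(NC(=O)OCC(C)C)cc2)cc1` — in an ADME assay on BEAS-2B cells (Homo sapiens) for cytotoxicity, read by MTT assay, with a stated time of 72 h (a lower number here means a stronger inhibitor of growth, a higher number a weaker inhibitor of growth), compound 1 gives 13100 nM
Compound 2 `CC(C)COC(=O)Nc1ccc([Se]C#N)cc1` — in this assay compound 2 gives 26900 nM

Compound 2 holds the higher of the two numbers, and so is the weaker inhibitor of cell growth of the pair. Its nearest neighbour is compound 1, whose value is lower by a margin that lies beyond the scatter of repeated measurements, so the two compounds are genuinely told apart by this assay. Compound 1 carries two carbamate-bearing aryl portions joined through a pair of selenium atoms, while compound 2 carries a single such portion with a selenocyanate group in its place.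

Compound 3 `N#C[Se]c1ccc(NC(=O)Oc2ccccc2)cc1` keeps the core of compound 2 and alters only the carbamate end: phenyl in place of isobutyl on an oxygen next to a carbonyl group. For the measured compounds named here, no measured pair shows this kind of exchange, so there is no step to lean on. The expectation is therefore a step of no clear size in this assay, none beyond the scatter, in either direction. On that basis compound 3 is estimated at 22000 nM, with a likely range from 8000 nM to 60000 nM, which corresponds to an expected step of a 1.2-fold lower number from compound 2 to compound 3 (0.09 log units; within the scatter).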

Compound 3, concentration for 50% growth inhibition: 8900 nM
Compound 3: middle estimate off by 2.5-fold (0.39 log units), on the high side; the range from low to high includes it.
By their numbers in this assay, from the lowest: compounds 3 and 1 (each within the scatter of the next); then compound 2.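

The carbamate end of the molecule matters in this measurement: in this assay, phenyl in place of isobutyl on an oxygen next to a carbonyl group gives a 3.0-fold lower number from compound 2 to compound 3 (0.48 log units; beyond the scatter), a change larger than repeated measurements would produce by chance. For the compounds shown here, this is the first comparison in which only the carbamate end differs, whereas compound 1 and compound 2 differ in the selenium-bearing part and so could say nothing about this position on its own. Nothing at hand explains why the phenyl version is the stronger inhibitor of growth of this pair.

A single step cannot show whether the shift belongs to the aromatic ring itself or simply to a larger group, and a cyclohexyl ring, a benzyl group or a longer chain on the same oxygen would help separate the two. Going by these compounds, it also remains open whether a phenyl ring carrying a fluorine or methoxy group would move the number further, and whether the same exchange would act alike on the pair of selenium atoms in compound 1.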